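Phenyl in Place of Methyl: Another Limit Expected

A few compounds are considered here, and "the series" means these few. Any claim that something is new, unique, unknown or untested is made for them only; others in the source may bear on it.

Compound 2 `COc1ccc(/C=N/N(C(C)=O)c2nc(C)c[se]2)cc1` — > 74300 nM (a limit of the assay)
Compound 1 `CC(=O)N(/N=C/c1ccc(Cl)cc1)c1nc(-c2ccccc2)c[se]1` — > 62000 nM (a limit of the assay)

In a functional assay on DU-145 cells (Homo sapiens) for cytotoxicity, read by XTT assay, with a stated time of 72 h (a higher number here means a weaker inhibitor, a lower number a stronger inhibitor), compound 2 gives > 74300 nM, which is a limit of the assay rather than a number. Compound 1 gives > 62000 nM, also a limit. So compound 2 stands on no scale at all: both values shown are limits, the limit of > 74300 nM in this assay, at which 1 of the 2 values shown sits, and (the limit of > 62000 nM in this assay, at which 1 of the 2 values shown sits), and neither compound can be placed above the other. Compound 3 `COc1ccc(/C=N/N(C(C)=O)c2nc(-c3ccccc3)c[se]2)cc1` differs from compound 2 in one place: phenyl in place of methyl on an aromatic carbon. Compound 1 already carries a phenyl at that spot and reached only a limit, so in this assay no step beyond the scatter is expected, and the likeliest outcome for compound 3 is once more a limit. The value expected for compound 3 is 75000 nM, between 20000 nM and 200000 nM. The step that the limit leaves unreadable from compound 2 to compound 3 that this estimate implies is expected to be no real change.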

Compound 3, half-maximal inhibitory concentration: > 62700 nM
Compound 3: a limit, no number; the forecaster's own chance of this, stated with the estimate: 85%; the middle value lies beyond the limit too.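

Compound 3 also gives only a limit in this assay, so the steps from compound 2 to compound 3 and from compound 1 to compound 3 cannot be read. From the compounds shown here alone, whether phenyl in place of methyl or methoxy in place of chloro changes the result at all stays open.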